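The source may report more compounds than this note shows. Statements on the series, on what has been measured and on what is new or still open speak of the compounds shown alone.

Compound 1 `NC(=O)CN(Cc1ccc(Cl)cc1)Cc1ccc([N+](=O)[O-])s1` carries a nitrothiophene arm and a chlorobenzyl arm on a central amine, with a short amide-bearing chain as the third substituent. In a functional assay on HEK293 cells for agonist activity at nuclear receptor subfamily 1 group D member 1 (Homo sapiens), read by a luciferase reporter, with a stated time of 24 h (a higher number here means that more compound is needed for the effect, a lower number that less compound is needed), compound 1 gives 3000 nM. Compound 2 `O=[N+]([O-])c1ccc(CN(Cc2ccc(Cl)cc2)CC2CCN(Cc3ccccc3)C2)s1` keeps the same two aromatic arms but replaces the short chain with a ring-bearing arm, a five-membered non-aromatic ring with one nitrogen that carries a benzyl group. In this assay compound 2 is recorded as "not determined" (no result reported), so compound 2 stands without a number and there is nothing to set it against compound 1.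

Compound 3 `CS(=O)(=O)N1CCC(CN(Cc2ccc(Cl)cc2)Cc2ccc([N+](=O)[O-])s2)C1` differs from compound 2 in one place: methylsulfonyl in place of benzyl on an amine nitrogen in a ring. Among the measured compounds shown here, no measured pair in this set shows what such a swap does, so there is no anchor for the size or direction of the step. For the measured compounds named here, the only measured point is compound 1, whose value in this assay is 3000 nM, and compound 3 shares with it the two aromatic arms. On that basis the expected value for compound 3 in this assay is estimated at 3000 nM, with a range from 700 nM to 15000 nM.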

Compound 3, half-maximal effective concentration: 570 nM
For compound 3 the middle estimate is 5.3-fold (0.72 log units) above the measured one, and the stated range ends above it.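

In this assay, the third arm on the central amine is not limited to a short chain: putting 1-(methylsulfonyl)pyrrolidin-3-yl in place of carbamoyl gives a 5.3-fold lower number from compound 1 to compound 3 (0.72 log units; beyond the scatter), a step beyond the usual scatter. Among the compounds shown here, this is the first number for an arm that bears a five-membered non-aromatic ring, and it shows that this larger arm can go with less compound needed for the effect. The swap of benzyl for methylsulfonyl on the ring nitrogen cannot be read, as compound 2 stands without a number, and nothing shown here gives a reason for the step that can be read.

The step from compound 1 to compound 3 replaces the whole arm at once, so the compounds shown do not separate what the ring contributes from what the methylsulfonyl group contributes. On these data alone, an acetyl group or a plain hydrogen on the ring nitrogen would help to separate them, as would an open chain ending in methylsulfonyl, and the effect of any of these on the number remains open.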